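Moving the halogens on the aryl group of compound 2

The compounds below may be only part of what the source reports. "The series", "measured", "known", "first", "only" and "open" are said of these compounds alone.

Going by the values given here, compound 2 `COc1cc(N(CC2CC2)c2cc(Cl)ccc2F)cnc1C(=O)[C@H]1C[C@@H]1C(=O)O` has been tested in an ADME assay on cells (Hepatocyte, Homo sapiens) for metabolic stability, read by LC-MS, with a stated time of 60 min, tested at 1 uM (a higher number here means faster removal of the compound, a lower number slower removal), and gives 1.3 uL/min, the lowest of the two numbers measured so far. Among the compounds with values here, compound 1 `COc1cc(N(CC2CC2)c2ccc(Cl)c(Cl)c2)cnc1C(=O)[C@H]1C[C@@H]1C(=O)O` gives 4.3 uL/min in this assay, and the single measured step, a 3.3-fold lower number from compound 1 to compound 2 (0.52 log units; beyond the scatter), came with 5-chloro-2-fluorophenyl in place of 3,4-dichlorophenyl on the nitrogen. Compound 3 `COc1cc(N(CC2CC2)c2ccc(F)c(Cl)c2)cnc1C(=O)[C@H]1C[C@@H]1C(=O)O` is not yet measured; it differs from compound 2 by 3-chloro-4-fluorophenyl in place of 5-chloro-2-fluorophenyl on a nitrogen on an aromatic ring. Within the data shown here, only that one step bears on the change, and it was modest. Since the 3-chloro-4-fluorophenyl of compound 3 resembles the 3,4-dichlorophenyl of compound 1 more than it does the group in compound 2, a partial return toward the number of compound 1 is expected. Compound 3 is therefore estimated at 3 uL/min in this assay, with a range from 1.3 uL/min to 7 uL/min. This estimate amounts to an expected step of a 2.3-fold higher number from compound 2 to compound 3 (0.36 log units; beyond the scatter).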

Compound 3, intrinsic clearance in a liver preparation (reported as CLH), per the amount of preparation that the assay uses: 3.1 uL/min
Beside the measured number, compound 3's estimate is 1.0-fold (0.01 log units) below it; low and high end bracket the measured number.
By their numbers in this assay, from the lowest: compound 2; then compounds 3 and 1 (each within the scatter of the next).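

Compound 3 has the same atoms as compound 2, so the step of a 2.4-fold higher number from compound 2 to compound 3 (0.38 log units; beyond the scatter) in this assay reflects only a rearrangement of the chlorine and fluorine on the aryl group. Fluoro in place of chloro, going the other way round the series, gives a 1.4-fold lower number from compound 1 to compound 3 (0.14 log units; within the scatter), so compound 1 and compound 3 cannot be told apart in this assay. Among these three compounds, then, the arrangement of the two halogens on the ring goes with a larger difference than the exchange of one halogen for the other.

As far as these compounds go, it remains open whether an aryl group carrying a nitrile or a trifluoromethyl instead of the halogens, or a plain phenyl, would reach a number as low as that of compound 2. Nothing measured here explains the difference between the arrangements.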